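Naphthalen-2-yl in place of 2-methoxyphenyl: cytotoxicity outlook

A few compounds are considered here, and "the series" means these few. Any claim that something is new, unique, unknown or untested is made for them only; others in the source may bear on it.

In an ADME assay on HCT-116 cells (Homo sapiens) for cytotoxicity, read by CellTiter-Glo, with a stated time of 72 h (a lower number here means a stronger inhibitor, a higher number a weaker inhibitor), compound 1 (`COc1ccccc1-c1cccc(S(=O)(=O)N2CCC(N3CCC(C)CC3)CC2)c1`) gives > 5000 nM as a limit and not a number. Compound 2 (`COc1cc(C)ccc1S(=O)(=O)N1CCC(N2CCC(C)CC2)CC1`) gives > 5000 nM as a limit too. Compound 3 (`Cc1ccc(C2CCN(S(=O)(=O)c3c(C)cc(C)cc3C)CC2)cc1`) gives > 5000 nM as a limit again. Compound 1 therefore has no exact number, and the series offers only the limit of > 5000 nM in this assay, at which 3 of the 3 values shown sit, as its record so far. Going by the values given here, compound 4 (`CC1CCN(C2CCN(S(=O)(=O)c3cccc(-c4ccc5ccccc5c4)c3)CC2)CC1`) carries naphthalen-2-yl in place of 2-methoxyphenyl on an aromatic carbon and no measured step exists to size this change. The expected change in this assay is a step that the limit leaves unreadable from compound 1 to compound 4 and no step beyond the scatter is expected in either direction. The estimate for compound 4 is 6000 nM with an expected range from 2500 nM to 20000 nM and a limit is quite likely.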

Compound 4, half-maximal inhibitory concentration: > 5000 nM
Compound 4: a limit, no number; the forecaster's own chance of this, stated with the estimate: 70%; the middle value does not contradict the limit.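

Compound 1 and compound 4 both stand at a limit in this assay, and no step can be read between them. The compounds shown leave open whether naphthalen-2-yl in place of 2-methoxyphenyl changes cytotoxicity at all.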